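This account rests on a few compounds, and the source may have more. Where it says the series, first, only, none or still open, it means among the compounds named here.

Measured in a functional assay on HeLa cells (Homo sapiens) for antiproliferative activity, read by CCK-8 assay, with a stated time of 72 h; a higher number here means a weaker inhibitor, a lower number a stronger inhibitor:
compound 1 `O=C(Nc1cccc(-c2oc3cc(-c4ccc(F)cc4)ccc3c(=O)c2O)c1)c1ccccc1F`: 5630 nM
compound 2 `O=C(Nc1cccc(-c2oc3cc(-c4ccc(F)cc4)ccc3c(=O)c2O)c1)c1ccc(F)cc1`: 5350 nM
compound 3 `O=C(Nc1cccc(-c2oc3cc(-c4ccc(F)cc4)ccc3c(=O)c2O)c1)c1ccc(F)cc1F`: 10700 nM

Compound 3 carries the highest of the three numbers, yet the steps of a 1.9-fold higher number from compound 1 to compound 3 (0.28 log units; within the scatter) and a 2.0-fold higher number from compound 2 to compound 3 (0.30 log units; within the scatter) both sit within the scatter, so no order among the three is established. Compound 4 `COc1ccc(C(=O)Nc2cccc(-c3oc4cc(-c5ccc(F)cc5)ccc4c(=O)c3O)c2)c(F)c1` differs from compound 3 by methoxy in place of fluoro on an aromatic carbon. For the measured compounds named here, no measured step trades fluoro for methoxy; the steps that exist, a 1.1-fold lower number from compound 1 to compound 2 (0.02 log units; within the scatter) and the two fluoro additions already named, all concern fluoro substitution on the phenyl attached to the carbonyl carbon, and none left the scatter. On that basis a change no larger than the scatter is expected, a 1.3-fold lower number from compound 3 to compound 4 (0.13 log units; within the scatter). Compound 4 is therefore estimated at 8000 nM in this assay, within 3500 nM to 18000 nM.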

Compound 4, half-maximal inhibitory concentration: 16100 nM
Compound 4: middle estimate off by 2.0-fold (0.30 log units), on the low side; low and high end bracket the measured number.
By their numbers in this assay, from the lowest: compounds 2, 1, 3 and 4 (each within the scatter of the next, the first and the last beyond it).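

In this assay, methoxy in place of fluoro at this position, para to a large group, gives a 1.5-fold higher number from compound 3 to compound 4 (0.18 log units; within the scatter), so the two groups are not separated here. Methoxy in place of hydrogen at the same position gives a 2.9-fold higher number from compound 1 to compound 4 (0.46 log units; beyond the scatter), and the wider change from the 4-fluorophenyl group gives a 3.0-fold higher number from compound 2 to compound 4 (0.48 log units; beyond the scatter); both are modest, yet they are the first steps in the series beyond the scatter. No measured property bears on these steps.

On these data alone, whether an amine or a carboxylic acid at this position would move the number beyond the scatter from compound 3 remains open. Also open, as far as these compounds go, is whether methoxy gives a similar number without the fluoro group meta to it.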